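The source may hold more compounds than are shown below. What is called first, only, known or untested is meant among the compounds shown, and "the series" means these compounds.

Working notes on the series. In a functional assay on MCF7 cells (Homo sapiens) for antiproliferative activity, read by MTT assay, with a stated time of 72 h (on this read-out lower numbers stand for stronger inhibition and higher numbers for weaker inhibition), compound 1, `CCN1CCN(c2cc(C)c3cc(NC(=O)c4cccnc4)ccc3n2)CC1`, gives 26600 nM. Two further amides share the core: compound 2, `Cc1cc(N2CCCCC2)nc2ccc(NC(=O)c3ccc(Cl)c(Cl)c3)cc12`, gives 31100 nM, and compound 3, `Cc1cc(N2CCCC2)nc2ccc(NC(=O)c3ccc(Cl)c(Cl)c3)cc12`, gives 26300 nM. Compound 1 sits among these three numbers, and all three lie within the scatter of one another; no order among them can be claimed. Among the compounds with values here, the only single-point step measured so far is a 1.2-fold lower number from compound 2 to compound 3 (0.07 log units; within the scatter), a change of the amine ring at the other end of the core.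

Compound 4, `CCN1CCN(c2cc(C)c3cc(NC(=O)c4ccccc4)ccc3n2)CC1`, differs from compound 1 in the amide part: phenyl in place of pyridin-3-yl on a carbonyl carbon. Within the data shown here, no measured step touches this position, and the amide ring has not been varied in a matched pair; the step from compound 2 to compound 3 therefore does not bear on it. The three measured values give no sign that any change tried so far moves this assay beyond its scatter. For compound 4 a number close to that of compound 1 is expected, with a step of a 1.1-fold higher number from compound 1 to compound 4 (0.02 log units; within the scatter). The estimate for compound 4 in this assay is 28000 nM, within the range 11000 nM to 75000 nM.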

Compound 4, half-maximal inhibitory concentration: 14200 nM
For compound 4 the middle estimate is 2.0-fold (0.29 log units) above the measured one; low and high end bracket the measured number.
By their numbers in this assay, from the lowest: compounds 4, 3, 1 and 2 (each within the scatter of the next, the first and the last beyond it).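

Within the data shown here, the first matched pair at the amide ring gives a 1.9-fold lower number from compound 1 to compound 4 (0.27 log units; within the scatter) in this assay, the largest single-point step seen so far, yet it still stays within the scatter. Phenyl in place of pyridin-3-yl on this carbonyl carbon therefore gives no measurable loss of activity in this pair, and the ring nitrogen of pyridin-3-yl is not needed to keep the number in this range. No measurement at hand explains the step, and none bears on what the ring nitrogen does at this position.

From the compounds shown here alone, whether a phenyl ring carrying an amino group or a carboxylic acid, or a saturated cyclohexyl ring, on this carbonyl carbon would move the number beyond the scatter remains open. Also open, going by these compounds, is whether the same exchange reads alike when pyrrolidin-1-yl sits at the other end of the shared core.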